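Shrinking a Tert-Butyl to a Methyl on Compound 1

A few compounds are considered here, and "the series" means these few. Any claim that something is new, unique, unknown or untested is made for them only; others in the source may bear on it.

Of the compounds shown here, two have so far been measured in an assay on microsomes from liver for inhibition of acyl-CoA desaturase 1 (Rattus norvegicus); a higher number here means a weaker inhibitor, a lower number a stronger inhibitor. Compound 1 `CC(C)(C)c1nnc(-c2ccc(N3CCC(Oc4ccccc4C(F)(F)F)CC3)nn2)s1` gives 710 nM in this assay. Compound 2 `FC(F)(F)c1ccc(OC2CCN(c3ccc(-n4ccnc4)nn3)CC2)cc1` gives 371 nM in this assay. Compound 1 shows the higher of the two numbers, but the gap between compound 1 and compound 2 falls within the scatter of repeated measurements, so the two cannot be told apart on these data.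

Compound 3 `Cc1nnc(-c2ccc(N3CCC(Oc4ccccc4C(F)(F)F)CC3)nn2)s1` has not yet been measured. It differs from compound 1 in a single place: methyl in place of tert-butyl on an aromatic carbon, that is, 5-(tert-butyl)-1,3,4-thiadiazol-2-yl becomes 5-methyl-1,3,4-thiadiazol-2-yl, with the rest of the shared core unchanged. Among the compounds with values here, no two measured compounds differ in just one place, so there is no measured step to lean on here. The expectation, resting only on compound 1 and its value, is a small step from compound 1 to compound 3 of a 1.7-fold higher number from compound 1 to compound 3 (0.23 log units; within the scatter) toward a higher number, with the real chance that it stays within the scatter. Compound 3 is therefore estimated at 1200 nM, with a plausible range from 300 nM to 5000 nM.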

Compound 3, half-maximal inhibitory concentration: 2.3 nM
Compound 3: the middle estimate sits 520-fold (2.72 log units) above what was measured; measured number outside the range, below it.
By their numbers in this assay, from the lowest: compound 3; then compounds 2 and 1 (each within the scatter of the next).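

Going from tert-butyl to methyl on this aromatic carbon, the one next to the ring nitrogen and the ring sulfur, gives in this assay a 310-fold lower number from compound 1 to compound 3 (2.49 log units; beyond the scatter) and shows that this single position has a very large bearing on the number, something the earlier compounds could not reveal because no two of them differed in just one place. By the counts, tert-butyl has 4 heavy atoms and methyl has 1, neither has a hydrogen-bond donor or acceptor or a net charge, and the rest of the shared core is unchanged. No supporting measurement is available to explain why a change this simple produces a step this large.

The compounds shown leave open how the number responds across the range of alkyl groups at this position, such as whether ethyl or isopropyl reads closer to methyl or to tert-butyl, and whether a plain hydrogen goes lower still. They also leave open what an amine or a methoxy group would do on the same carbon.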